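Triazole substituent swap on the shared lactone core

This account rests on a few compounds, and the source may have more. Where it says the series, first, only, none or still open, it means among the compounds named here.

Measured so far:
compound 1 `O=C1O[C@H]([C@@H](O)Cn2cc(-c3cc(F)cc(F)c3)nn2)C(OCc2ccccc2)=C1OCc1ccccc1` — 40800 nM
compound 2 `O=C1O[C@H]([C@@H](O)Cn2cc(CNS(=O)(=O)c3ccc(F)cc3)nn2)C(OCc2ccccc2)=C1OCc1ccccc1` — 25000 nM
compound 3 `C[Si](C)(C)c1cn(C[C@H](O)[C@H]2OC(=O)C(OCc3ccccc3)=C2OCc2ccccc2)nn1` — 22300 nM

All three were read in a functional assay on HeLa cells (Homo sapiens) for antiproliferative activity, read by MTT assay, with a stated time of 72 h; on this read-out higher numbers stand for weaker inhibition and lower numbers for stronger inhibition. Compound 3 sits within the scatter of the other two: the step of a 1.8-fold lower number from compound 1 to compound 3 (0.26 log units; within the scatter) and the step of a 1.1-fold lower number from compound 2 to compound 3 (0.05 log units; within the scatter) are both small, as is a 1.6-fold lower number from compound 1 to compound 2 (0.21 log units; within the scatter). Nothing among these three numbers separates one substituent on the triazole from another.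

Compound 4 `COc1ccc(-c2cn(C[C@H](O)[C@H]3OC(=O)C(OCc4ccccc4)=C3OCc3ccccc3)nn2)cc1` carries the change (a group of 8 heavy atoms (7 carbon, 1 oxygen; one six-membered aromatic ring of carbon only) in place of a group of 4 heavy atoms (3 carbon, 1 silicon; no ring), on an aromatic carbon). Among the compounds with values here, the step that bears on it is the reverse of the one from compound 1 to compound 3, where a six-membered aromatic ring of carbon only gave way to the silicon-bearing group and the number moved by a 1.8-fold lower number from compound 1 to compound 3 (0.26 log units; within the scatter), within the scatter. Putting an aromatic ring back in the same place is therefore expected to move the number little. For compound 4 the expectation is a step of a 1.3-fold higher number from compound 3 to compound 4 (0.13 log units; within the scatter), that is, no change beyond the scatter. Compound 4 is estimated at 30000 nM, with a range from 12000 nM to 75000 nM.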

Compound 4, half-maximal inhibitory concentration: 16400 nM
Estimate against measurement, compound 4: 1.8-fold (0.26 log units) above; measured number inside the range.
By their numbers in this assay, from the lowest: compounds 4, 3, 2 and 1 (each within the scatter of the next, the first and the last beyond it).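

In this assay, within the data shown here, there is a 2.5-fold lower number from compound 1 to compound 4 (0.40 log units; beyond the scatter) on placing 4-methoxyphenyl where 3,5-difluorophenyl stood, the first step beyond the scatter, and it falls between two groups that both put a six-membered aromatic ring on the same aromatic carbon. The other two new steps, a 1.4-fold lower number from compound 3 to compound 4 (0.13 log units; within the scatter) and a 1.5-fold lower number from compound 2 to compound 4 (0.18 log units; within the scatter), stay within the scatter, so 4-methoxyphenyl is not separated from the silicon-bearing group or from (((4-fluorophenyl)sulfonyl)amino)methyl. Among these compounds, no measurement at hand explains the one step beyond the scatter.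

As far as these compounds go, whether that step follows from the methoxy group entering or from the two fluorine atoms leaving remains open. Also open, from the compounds shown here alone, is how an amine or a carboxylic acid on this aromatic carbon would read.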